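Capping the Phenol: From Compound 2 to Compound 3

A few compounds are considered here, and "the series" means these few. Any claim that something is new, unique, unknown or untested is made for them only; others in the source may bear on it.

Compound 2 `CC1(C)C=C(n2ccccc2=O)c2cc(O)ccc2O1` is the less potent of the two compounds measured in a functional assay (trachea) with Rattus norvegicus as the target; a lower number here means a less potent compound, a higher number a more potent compound, by a factor of ten per unit of this negative logarithm: compound 2 gives 5.31, while compound 1 `CC(=O)c1ccc2c(c1)C(n1ccccc1=O)=CC(C)(C)O2` gives 6.65. Compound 3 `CC(=O)Oc1ccc2c(c1)C(n1ccccc1=O)=CC(C)(C)O2` differs from compound 2 by acetyl in place of hydrogen on an oxygen on an aromatic ring. Among the measured compounds shown here, the only measured step, a number 1.34 log units lower from compound 1 to compound 2 (beyond the scatter), swapped groups on an aromatic carbon rather than on an oxygen on an aromatic ring, so it bears on this change only loosely, though it shows the acetyl-bearing compound 1 well ahead. A moderate rise is therefore expected, a number 0.49 log units higher from compound 2 to compound 3 (beyond the scatter). Compound 3 is estimated at 5.8, between 5 and 6.6.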

Compound 3, logarithm of the reciprocal of the active concentration, log(1/C): 4.97
Compound 3: middle estimate off by 0.83 log units, on the high side, outside the stated range (below it).
By their numbers in this assay, from the lowest: compound 3; then compound 2; then compound 1.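

In this assay the hydroxy of compound 2 does not gain from capping, since acetyl on this oxygen gives a number 0.34 log units lower from compound 2 to compound 3 (beyond the scatter) and so the acetyl group's benefit in compound 1 does not carry over to this position. Moving from acetyl to acetoxy on the aromatic carbon gives a number 1.68 log units lower from compound 1 to compound 3 (beyond the scatter) and shows that inserting an oxygen between ring and acetyl matters greatly. Nothing available explains either drop. Still open, on these data alone, is how an amine on this aromatic carbon, or a longer chain than acetyl on this oxygen, would compare.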